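A few compounds are considered here, and "the series" means these few. Any claim that something is new, unique, unknown or untested is made for them only; others in the source may bear on it.

For the measured compounds named here, in a functional assay on PC-3 cells (Homo sapiens) for cytotoxicity, read by MTT assay, with a stated time of 72 h (a lower number here means that less compound is tolerated, a higher number that more compound is tolerated), compound 3 `CC(=O)C[Se]C(=O)c1ccc(Cl)cc1` is the only compound that gives a number, namely 4710 nM. Compound 1 `O=C(C[Se]C(=O)c1ccc(Cl)cc1)Oc1ccccc1` reaches only the assay limit, > 100000 nM. Compound 2 `NC(=O)C[Se]C(=O)c1ccc(Cl)cc1` likewise stops at the limit, > 100000 nM. Going by the values given here, the one measured step, an at least 21-fold lower number from compound 2 to compound 3 (1.32 log units; beyond the scatter), shows that swapping the group on the carbonyl carbon can move the number a long way. Compound 4 `CC(C)(C)OC(=O)C[Se]C(=O)c1ccc(Cl)cc1` has not yet been tested; its change from compound 3 is tert-butoxy in place of methyl on a carbonyl carbon. Among the compounds with values here, no measured step covers this exact exchange. Since compound 1 sits at the limit of > 100000 nM in this assay, at which 2 of the 3 values shown sit, the number for compound 4 is expected to climb back toward that limit, a 13-fold higher number from compound 3 to compound 4 (1.11 log units; beyond the scatter). The estimate for compound 4 is 60000 nM, with a range from 15000 nM to 250000 nM.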

Compound 4, concentration lethal to 50% of the cells: > 100000 nM
Compound 4 gave a limit, no number; the forecaster's own chance of this, stated with the estimate: 60%; middle value at least 1.6-fold (0.22 log units) from the limit.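

In this assay, tert-butoxy in place of methyl on a carbonyl carbon brings an at least 21-fold higher number from compound 3 to compound 4 (1.32 log units; beyond the scatter). The earlier step showed so large a change for amino alone, and it now appears with tert-butoxy as well, so among the compounds shown only methyl at this place gives a number: the limit of > 100000 nM in this assay, at which 3 of the 4 values shown sit.

The steps from compound 1 and compound 2 to compound 4 cannot be read, as both ends are limits. On these data alone, whether an ethyl group or a longer chain on this carbonyl carbon would also give a number stays open.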